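Ring swap at the aryl position: piperidinyl for pyrazolyl

The compounds below may be only part of what the source reports. "The series", "measured", "known", "first", "only" and "open" are said of these compounds alone.

Measured compounds in a functional assay for inhibition of sodium/hydrogen exchanger (Oryctolagus cuniculus); a higher number here means a weaker inhibitor, a lower number a stronger inhibitor:
compound 1 `Cc1cc(-c2ccc(Cl)cc2Cl)c(S(C)(=O)=O)cc1C(=O)N=C(N)N` gives 42 nM
compound 2 `CS(=O)(=O)c1cc(C(=O)N=C(N)N)ccc1-n1cccn1` gives 160 nM
compound 3 `Cc1cc(-n2cccn2)c(S(C)(=O)=O)cc1C(=O)N=C(N)N` gives 25 nM

Compound 2 gives the highest number of the three; compound 1 is nearest, compound 3 furthest. Compound 4 `CS(=O)(=O)c1cc(C(=O)N=C(N)N)ccc1N1CCCCC1` has not been measured. It differs from compound 2 in one place: piperidin-1-yl in place of 1H-pyrazol-1-yl on an aromatic carbon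

Of the measured steps, only a 1.7-fold lower number from compound 1 to compound 3 (0.23 log units; within the scatter) concerns the same position, and it is small. The step of a 6.4-fold lower number from compound 2 to compound 3 (0.81 log units; beyond the scatter) concerns methyl at another position and does not bear on this change. Given that the exchange at this carbon between compound 1 and compound 3 moved the number little, compound 4 is expected to stay near compound 2, with a 1.1-fold lower number from compound 2 to compound 4 (0.03 log units; within the scatter) not beyond the scatter. Compound 4 is estimated at 150 nM, within 60 nM to 400 nM.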

Compound 4, half-maximal inhibitory concentration: 130 nM
The estimate for compound 4 lay 1.2-fold (0.06 log units) above the measured number; the range from low to high includes it.
By their numbers in this assay, from the lowest: compounds 3 and 1 (each within the scatter of the next); then compounds 4 and 2 (each within the scatter of the next).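

In this assay, piperidin-1-yl replaces 1H-pyrazol-1-yl with a 1.2-fold lower number from compound 2 to compound 4 (0.09 log units; within the scatter), so on the core of compound 2 this carbon, ortho to a methylsulfonyl group, takes a six-membered non-aromatic ring without a change beyond the scatter. The earlier exchange at this carbon, a 1.7-fold lower number from compound 1 to compound 3 (0.23 log units; within the scatter), involved only aromatic rings and a methyl-bearing core. No measurement at hand accounts for this result.

Still open, as far as these compounds go, is whether an open-chain amine such as dimethylamino, or morpholin-4-yl, behaves likewise at this carbon. Also open, from the compounds shown here alone, is whether methyl on the core of compound 4 repeats a 6.4-fold lower number from compound 2 to compound 3 (0.81 log units; beyond the scatter).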